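A few compounds are considered here, and "the series" means these few. Any claim that something is new, unique, unknown or untested is made for them only; others in the source may bear on it.

Compound 1 `CC/C=C\C/C=C\C/C=C\CCCCCCCc1cc(O)cc(O)c1` and compound 2 `CCCCCC[C@H](O)C/C=C\CCCCCCCc1cc(O)cc(O)c1` share one core and differ only within the chain. In a functional assay on MCF7 cells (Homo sapiens) for cytotoxicity (a higher number here means a weaker inhibitor, a lower number a stronger inhibitor), compound 1 gives 8700 nM, while compound 2 gives 14000 nM. Compound 2 thus holds the higher of the two recorded numbers, though its gap to compound 1 lies within the scatter. In this assay compound 3 `CCCCC/C=C\C/C=C\CCCCCCCc1cc(OC(C)=O)cc(OC(C)=O)c1` gives "not determined" (no result reported). Compound 4 `CC/C=C\C[C@@H](O)CC/C=C\CCCCCCCc1cc(O)cc(O)c1` differs from compound 2 by a group of 8 heavy atoms (7 carbon, 1 oxygen; no ring) in place of a group of 8 heavy atoms (7 carbon, 1 oxygen; no ring), on a saturated chain carbon bound to a double-bonded chain carbon; the entering group carries one double bond outside aromatic rings. Among the compounds with values here, the only step bearing on this, a 1.6-fold higher number from compound 1 to compound 2 (0.21 log units; within the scatter), stayed within the scatter, so no shift beyond it is expected. Compound 4 is therefore expected at about 11000 nM, within a range from 4500 nM to 28000 nM. That expectation amounts to a step of a 1.3-fold lower number from compound 2 to compound 4 (0.10 log units; within the scatter).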

Compound 4, half-maximal inhibitory concentration: 22000 nM
Compound 4: middle estimate off by 2.0-fold (0.30 log units), on the low side; measured number inside the range.
By their numbers in this assay, from the lowest: compounds 1, 2 and 4 (each within the scatter of the next, the first and the last beyond it).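

In this assay, exchanging 1-hydroxyheptyl for the group in compound 4, which has one double bond outside aromatic rings, gives a 1.6-fold higher number from compound 2 to compound 4 (0.20 log units; within the scatter), so the two groups cannot be told apart. Within the data shown here, the other step, a 2.5-fold higher number from compound 1 to compound 4 (0.40 log units; beyond the scatter), is the first here to pass the scatter, showing that a change on this saturated chain carbon can shift the number, though only modestly. No measurement shown explains this shift. From the compounds shown here alone, whether an amine, a carboxylic acid or a longer chain at this place would shift the number further remains open. So does the effect of reversing the defined stereocentre in compound 4.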